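A Fluorophenyl Group on a Weak Compound

The source may hold more compounds than are shown below. What is called first, only, known or untested is meant among the compounds shown, and "the series" means these compounds.

Measured in a functional assay on SW620/5-FU cells (Homo sapiens) for cytotoxicity, read by MTT assay, with a stated time of 48 h, in the presence of a further agent that is not named here; a higher number here means that more compound is needed for the effect, a lower number that less compound is needed:
- compound 1 `CCCc1cc(NNC(=O)Nc2cc(Cl)nc(Cl)c2)nc2c1c(C)nn2C`: 40800 nM
- compound 2 `Cc1cc(NNC(=O)Nc2cc(Cl)nc(Cl)c2)nc2c1c(C)nn2C`: > 100000 nM, a limit

Compound 2 gives no number in this assay, only the limit > 100000 nM. Compound 3 `Cc1nn(C)c2nc(NNC(=O)Nc3cc(Cl)nc(Cl)c3)cc(-c3ccc(F)cc3)c12` differs from it by 4-fluorophenyl in place of methyl on an aromatic carbon. For the measured compounds named here, the one measured step that bears on this change is an at least 2.4-fold higher number from compound 1 to compound 2 (0.38 log units; beyond the scatter), with hydrogen in place of ethyl on the chain at that same group. Losing chain there raised the number, so a much larger group is expected to lower it, though a single step is thin support and 4-fluorophenyl is no chain. The expected step is an at least 4.0-fold lower number from compound 2 to compound 3 (0.60 log units; beyond the scatter). Compound 3 is estimated at 25000 nM, with an expected range of 6000 nM to 100000 nM.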

Compound 3, half-maximal effective concentration: 17400 nM
Beside the measured number, compound 3's estimate is 1.4-fold (0.16 log units) above it, and the stated range covers the measured number.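

Replacing methyl with 4-fluorophenyl on this aromatic carbon gives an at least 5.7-fold lower number from compound 2 to compound 3 (0.75 log units; beyond the scatter). That step starts from compound 2's limit and not from a number: the limit of > 100000 nM in this assay, at which 1 of the 3 values shown sits. Replacing propyl with the same group gives a 2.3-fold lower number from compound 1 to compound 3 (0.37 log units; beyond the scatter), so at this position the aromatic ring lowers the number further than the longer chain does, and none of the three compounds goes against this order. Still open, from the compounds shown here alone, is whether the ring or its fluorine accounts for the step, which plain phenyl would help to separate, and how an amine or a carboxylic acid would read here.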